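The compounds below may be only part of what the source reports. "The series", "measured", "known", "first", "only" and "open" are said of these compounds alone.

Measured compounds:
compound 1 `Cc1cc(C(=O)c2ccccc2)ccc1OCC(=O)Nc1nc(-c2ccccc2)cs1`, 22300 nM;
compound 2 `Cc1ccc(C(=O)c2ccc(OCC(=O)Nc3nc(-c4ccccc4)cs3)c(C)c2)cc1`, 26400 nM;
compound 3 `O=C(COc1ccc(C(=O)c2ccccc2)cc1Br)Nc1nc(-c2ccccc2)cs1`, not yet measured.

Among the compounds with values here, in a functional assay on DLA cells (Mus musculus) for cytotoxicity, read by MTT assay, with a stated time of 48 h (a higher number here means a weaker inhibitor, a lower number a stronger inhibitor), compound 1 gives 22300 nM, the lowest of the two numbers so far; its nearest neighbour, compound 2, gives 26400 nM, and the step of a 1.2-fold higher number from compound 1 to compound 2 (0.07 log units; within the scatter) stays within the scatter, so the two are indistinguishable. The change to compound 3 is bromo in place of methyl on an aromatic carbon, placed ortho to a large group and meta to a benzoyl group. Within the data shown here, no measured step swaps methyl for bromo, so nothing bears on it directly; the only step known, from compound 1 to compound 2, shows that adding a methyl elsewhere barely moved this assay. Among the measured compounds shown here, with that as the sole guide, the expected step of a 1.1-fold lower number from compound 1 to compound 3 (0.05 log units; within the scatter) in this assay is small and without a clear direction. Compound 3 is therefore estimated at 20000 nM, with a likely range from 8000 nM to 50000 nM.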

Compound 3, half-maximal inhibitory concentration: 43100 nM
Beside the measured number, compound 3's estimate is 2.2-fold (0.33 log units) below it; measured number inside the range.
By their numbers in this assay, from the lowest: compounds 1, 2 and 3 (each within the scatter of the next).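

In this assay, bromo in place of methyl on this aromatic carbon, ortho to a large group and meta to a benzoyl group, gives a 1.9-fold higher number from compound 1 to compound 3 (0.29 log units; within the scatter) in the assay read-out. Within the data shown here, the earlier step, with its added methyl, concerned a different place in the molecule, so this is the only direct look at this position. The step is larger than that earlier one, but it is still within the scatter, so compound 1 and compound 3 cannot be told apart, and methyl and bromo show no measurable difference here.

The compounds shown leave open how an amine or a carboxylic acid on this same carbon would read in this assay. They also leave this result without support from any further measurement that could explain it.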